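The source may hold more compounds than are shown below. What is called first, only, known or untested is meant among the compounds shown, and "the series" means these compounds.

Measured compounds:
compound 1, `COc1ccc(/C=N/NC(=O)c2ccc(C)cc2O)cc1`, > 100000 nM (a limit, not a number)
compound 2, `Cc1ccc(C(=O)N/N=C/c2ccccc2F)c(O)c1`, 42100 nM
compound 3, `Cc1ccc(C(=O)N/N=C/c2cccc(F)c2)c(O)c1`, 31200 nM

Compound 1 gives only a limit in a functional assay (Mus musculus, strain BALB/C) for inhibition, read by MTT assay, with stated times of 24 h and 72 h (on this read-out lower numbers stand for stronger inhibition and higher numbers for weaker inhibition), so no number stands for it. Among the two numbers that are present, compound 2 has the higher one, but its gap to compound 3 is within the usual scatter of this assay, so the two cannot be ordered against each other. The two numbers that are present both lie far from any strong inhibition.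

Compound 4, `Cc1ccc(C(=O)N/N=C/c2ccccc2[N+](=O)[O-])c(O)c1`, has not been measured in this assay. It differs from compound 2 by nitro in place of fluoro on an aromatic carbon. For the measured compounds named here, no step between measured compounds joins a pair that shows the effect of this exchange, so nothing points to a direction. The two measured numbers sit close together, and on that basis the step in this assay is expected to stay within the scatter, with no clear direction either way.

For compound 4 the expected step is a 1.1-fold lower number from compound 2 to compound 4 (0.04 log units; within the scatter). The estimate for compound 4 in this assay is 38000 nM, with a range from 12000 nM to 100000 nM that reflects the absence of any measured step for this change.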

Compound 4, half-maximal inhibitory concentration: > 100000 nM
Compound 4 ended at the assay's limit; the forecaster's own chance of this, stated with the estimate: 20%; middle value at least 2.6-fold (0.42 log units) from the limit.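

In this assay, for the compounds shown here, nitro in place of fluoro on an aromatic carbon, ortho to a large group, gives the first step that can be read for this change: an at least 2.3-fold higher number from compound 2 to compound 4 (0.37 log units; beyond the scatter). Going by these compounds alone, the position is therefore not indifferent to what it carries, as the exchange moves the read-out toward weaker inhibition by more than the scatter, something compound 2 and compound 3 could not show with fluoro as the only group compared. Compound 4 gives > 100000 nM, which is a limit of the assay and not a number, so the step fixes only a minimum size and its true size stays unread: the limit of > 100000 nM in this assay, at which 2 of the 4 values shown sit.

As far as these compounds go, whether an amine or a carboxylic acid in the same place on the ring would leave the read-out near that of compound 2 or would also reach the limit stays open, so a single exchange cannot yet separate an effect of nitro itself from a general intolerance of replacing fluoro here. Also open, from the compounds shown here alone, is whether nitro would give a similar step at the place that fluoro holds in compound 3.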